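Swapping a Lactam Chain for a Carbamoylpiperidine

The source may report more compounds than this note shows. Statements on the series, on what has been measured and on what is new or still open speak of the compounds shown alone.

Of the compounds shown here, three sharing one core have been tested in an in vitro functional assay on B300-19 cells for antagonist activity at C-C chemokine receptor type 4 (Homo sapiens), read by GTPgammaS binding, tested at 1 uM; a lower number here means less inhibition, a higher number more inhibition at the concentration tested (going by the name of the read-out). Compound 1 `COc1cc2nc(NCc3ccccc3)nc(NC3CCCCCC3)c2cc1OC` gives 13%. Compound 2 `COc1cc2nc(N3CCC(Cc4ccccc4)CC3)nc(NC3CCCCCC3)c2cc1OC` gives 1%. Compound 3 `COc1cc2nc(NCCCN3CCCC3=O)nc(NC3CCCCCC3)c2cc1OC` gives 8%. All three numbers lie within the usual scatter of one another, so none can be called stronger or weaker than another; the values of compound 3 and compound 1 sit closest, and those of compound 3 and compound 2 lie furthest apart, yet still within the scatter.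

For the measured compounds named here, the only single-point step among them, a number 5 percentage points lower from compound 1 to compound 3 (within the scatter), shows that exchanging the phenyl for the 2-(2-oxopyrrolidin-1-yl)ethyl left the read-out unchanged in practice.

Compound 4 `COc1cc2nc(N3CCC(C(N)=O)CC3)nc(NC3CCCCCC3)c2cc1OC` is not yet measured. It differs from compound 3 in one place: 4-carbamoylpiperidin-1-yl in place of (3-(2-oxopyrrolidin-1-yl)propyl)amino on an aromatic carbon. Going by the values given here, compound 2 also carries a piperidine-based group at that same aromatic carbon and returned a low number, but no step to it has been computed, so only its value can be cited. Nothing in the three measurements points to a change beyond the scatter; the step of a number 3 percentage points lower from compound 3 to compound 4 (within the scatter) is therefore expected to be small. Compound 4 is estimated at 5%, within 0% to 15%.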

Compound 4, a percentage reported as inhibition, at one concentration (the size of the read-out at that concentration, not a potency): 17%
Compound 4: the middle estimate sits 12 percentage points below what was measured; the measured number lies above the stated range.
By their numbers in this assay, from the lowest: compounds 2, 3, 1 and 4 (each within the scatter of the next, the first and the last beyond it).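

At the aromatic carbon between two ring nitrogen atoms, the piperidine-based groups of compound 2 and compound 4 now allow a change on the saturated ring carbon to be read in this assay: with carbamoyl in place of benzyl, the result is a number 16 percentage points higher from compound 2 to compound 4 (beyond the scatter) and is the only step among these compounds to pass beyond the scatter. The change of the whole group gives no such separation, with 4-carbamoylpiperidin-1-yl in place of (3-(2-oxopyrrolidin-1-yl)propyl)amino giving a number 9 percentage points higher from compound 3 to compound 4 (within the scatter) and the same group in place of benzylamino giving a number 4 percentage points higher from compound 1 to compound 4 (within the scatter). No accompanying measurement accounts for the step from benzyl to carbamoyl.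

The compounds shown leave open whether a carboxylic acid, an amine or a longer chain ending in carbamoyl on that saturated ring carbon would give a number apart from that of compound 4. They also leave open how the carbamoyl group would read with a cyclopentylamino group in place of the cycloheptylamino group kept throughout these compounds.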